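A few compounds are considered here, and "the series" means these few. Any claim that something is new, unique, unknown or untested is made for them only; others in the source may bear on it.

Measured so far in an ADME assay on microsomes from liver (Rattus norvegicus) for metabolic stability, read by LC-MS, using NADPH, with a stated time of 10 min, tested at 0.5 uM; on this read-out higher numbers stand for a more stable compound and lower numbers for a less stable compound:
- Compound 1 `COC(=O)Nc1cc(-c2cc(C)c(OC[C@@](C)(N)CC(C)C)cn2)ccn1`: 100%
- Compound 2 `Cc1cc(-c2cc(C)c(OC[C@@](C)(N)CC(C)C)cn2)ccn1`: 72%

Compound 2 holds the lower of the two numbers, and a number 28 percentage points lower from compound 1 to compound 2 (beyond the scatter) is a modest step beyond the scatter. That step is the only measured one, and it brought in the methyl group on an aromatic carbon. Compound 3 `Cc1cc(-c2ccnc(C(F)F)c2)ncc1OC[C@@](C)(N)CC(C)C` gives up that same methyl: difluoromethyl in place of methyl on an aromatic carbon, next to the ring nitrogen. For the measured compounds named here, no measured step involves difluoromethyl, so the data give no direction for this change. The size of a number 28 percentage points lower from compound 1 to compound 2 (beyond the scatter) serves only as a guide to how far one substitution can move this read-out. The expected a number 3 percentage points higher from compound 2 to compound 3 (within the scatter) stays within the scatter, with a wide margin either way. For compound 3 the estimate is 75%, with an expected range of 55% to 93%.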

Compound 3, percent of the compound remaining: 76%
Compound 3: middle estimate off by 1 percentage points, on the low side, within the range that was stated.
By their numbers in this assay, from the lowest: compounds 2 and 3 (each within the scatter of the next); then compound 1.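

In this assay, difluoromethyl in place of methyl on an aromatic carbon, next to the ring nitrogen, gives a number 4 percentage points higher from compound 2 to compound 3 (within the scatter), so this read-out does not separate the two groups at this position. Difluoromethyl in place of (methoxycarbonyl)amino gives a number 24 percentage points lower from compound 1 to compound 3 (beyond the scatter), so the gap to compound 1 now appears with two different replacing groups rather than with methyl alone. No measurement here bears on the reason for these numbers.

The compounds shown leave open whether any other group at this position, such as an amine, trifluoromethyl or a longer chain, stays with compound 2 and compound 3 or comes closer to compound 1. They also leave open whether a smaller carbamate or a simple amide would hold the number of compound 1.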